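This account rests on a few compounds, and the source may have more. Where it says the series, first, only, none or still open, it means among the compounds named here.

Of the compounds shown here, three sharing one core have been measured in a functional assay on HepG2 cells (Homo sapiens) for inhibition, read by MTT assay, with a stated time of 120 h; on this read-out higher numbers stand for weaker inhibition and lower numbers for stronger inhibition. In this assay compound 1 `O=C(/C=C/c1ccc(NC(=O)Nc2ccc(Cl)c(C(F)(F)F)c2)cc1)NC1CCC1` gives 7510 nM. Compound 2 `CNC(=O)/C(C)=C/c1ccc(NC(=O)Nc2ccc(Cl)c(C(F)(F)F)c2)cc1` gives 44300 nM. That is a 5.9-fold higher number from compound 1 to compound 2 (0.77 log units; beyond the scatter), with 2-(methylcarbamoyl)prop-1-en-1-yl in place of 2-(cyclobutylcarbamoyl)ethenyl on an aromatic carbon.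

Compound 3 `CC(NC(=O)CCc1ccc(NC(=O)Nc2ccc(Cl)c(C(F)(F)F)c2)cc1)c1ccccc1` has no number, only a limit of the assay, > 50000 nM. It therefore stands at the limit of > 50000 nM in this assay, at which 1 of the 3 values shown sits.

The next compound, compound 4 `O=C(CCc1ccc(NC(=O)Nc2ccc(Cl)c(C(F)(F)F)c2)cc1)NC1CCC1`, differs from it as follows: cyclobutyl in place of 1-phenylethyl on an amide-type nitrogen. In words, cyclobutyl stands in place of 1-phenylethyl on an amide-type nitrogen.

Going by the values given here, only one measured step bears on this change, and only indirectly, since it alters more than the group on that nitrogen: a 5.9-fold higher number from compound 1 to compound 2 (0.77 log units; beyond the scatter). The cyclobutyl that compound 4 takes up is also carried by compound 1 , at 7510 nM, the lower of the two numbers in that step. A move to a lower number, meaning stronger inhibition, is therefore expected in this assay, and it is expected to be modest, estimated as an at least 2.7-fold lower number from compound 3 to compound 4 (0.44 log units; beyond the scatter). Compound 4 is expected at 18000 nM, with an estimated range from 6000 nM to 50000 nM.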

Compound 4, half-maximal inhibitory concentration: > 50000 nM
Compound 4: no number, only a limit (the forecaster's own chance of this, stated with the estimate: 30%); middle value at least 2.7-fold (0.44 log units) from the limit.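

In this assay, compound 4 gives only a limit of the assay, as compound 3 does, so the exchange of 1-phenylethyl for cyclobutyl on the amide-type nitrogen cannot be read, and no step between these two can be sized: the limit of > 50000 nM in this assay, at which 2 of the 4 values shown sit.

What the result adds is a comparison that holds the cyclobutyl amide fixed and changes only the chain, with 2-(cyclobutylcarbamoyl)ethyl in place of 2-(cyclobutylcarbamoyl)ethenyl, giving an at least 6.6-fold higher number from compound 1 to compound 4 (0.82 log units; beyond the scatter). Cyclobutyl on that nitrogen therefore does not by itself secure a measurable number, and in this one pair the ethenyl form gives the stronger inhibition. The comparison with the methylcarbamoyl compound, an at least 1.1-fold higher number from compound 2 to compound 4 (0.05 log units; that floor lies within the scatter), sets no order between them, since its floor lies within the scatter.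

The compounds shown leave open whether 1-phenylethyl on the amide-type nitrogen would matter at all once the chain is the ethenyl one, since the effect of that group is hidden behind the limit. They also leave open whether a carboxylic acid in place of the amide, or a longer chain carrying the cyclobutyl amide, would give a readable number.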